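The source may hold more compounds than are shown below. What is called first, only, known or untested is meant among the compounds shown, and "the series" means these compounds.

Compounds measured so far in a functional assay on BV-2 cells (Mus musculus, strain C57BL6/J) for inhibition, read by Griess assay, with a stated time of 24 h; on this read-out higher numbers stand for weaker inhibition and lower numbers for stronger inhibition:

Compound 1, `COC(=O)CC1=CC[C@H]2[C@H](C[C@@H]1C)OC(=O)[C@H]2C`, gives > 10000 nM, a limit of the assay.
Compound 2, `C[C@@H]1C(=O)O[C@H]2C[C@H](C)C(C(=O)O)=CC[C@@H]21`, gives > 10000 nM, also a limit of the assay.
Compound 3, `CC(=O)/C=C/C1=CC[C@H]2[C@H](C[C@@H]1C)OC(=O)[C@@H]2C`, gives 3700 nM.

Among the compounds with values here, compound 3 therefore stands alone as the only compound with an actual number in this assay; the other two results are limits. Within the data shown here, the one step that can be drawn between measured compounds, a step that the two limits leave unreadable from compound 1 to compound 2, runs between two limits and its size cannot be read, which is stated by the limit of > 10000 nM in this assay, at which 2 of the 3 values shown sit.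

Compound 4, `CC(=O)/C=C/C1=CC[C@H]2[C@H](C[C@@H]1C)OC(=O)[C@H]2C`, is the compound still to be measured. Compared with compound 3, (the two compounds have the same atoms and bonds and differ only in configuration as drawn: 1 of 5 stereo elements differ; a stereocentre at a saturated ring carbon is drawn R in compound 3 and S in compound 4). Among the measured compounds shown here, none of the measured steps involves a change of configuration alone, so no measured step bears on this change, and the unreadable step between compound 1 and compound 2 gives no guidance either. With nothing to point one way or the other, the expectation for this assay is a step of a 1.1-fold higher number from compound 3 to compound 4 (0.03 log units; within the scatter) from compound 3, that is, no change beyond the scatter, while leaving room for either direction. Compound 4 is thus estimated at 4000 nM, within a range from 1200 nM to 12000 nM.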

Compound 4, half-maximal inhibitory concentration: > 10000 nM
Compound 4 gave a limit, no number; the forecaster's own chance of this, stated with the estimate: 25%; at least 2.5-fold (0.39 log units) between middle value and limit.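

The change from R to S as drawn at this saturated ring carbon gives an at least 2.7-fold higher number from compound 3 to compound 4 (0.43 log units; beyond the scatter) in this assay. The earlier compounds shown here showed nothing about configuration, and here the step can be tied to that one stereocentre and to nothing else: the fact that compounds 3 and 4 differ only in the configuration as drawn. The 2-acetylethenyl group on the double-bonded ring carbon therefore does not secure a measurable number by itself, since compound 4 carries it as well and its result is only a limit, one shared with both other compounds that lack a number: the limit of > 10000 nM in this assay, at which 3 of the 4 values shown sit.

The steps linking compound 4 to compound 1 and to compound 2 run between two limits and cannot be read, so the compounds shown do not tell how much 2-acetylethenyl differs from carboxy or (methoxycarbonyl)methyl, nor how far compound 4 lies past its limit. Also open, from the compounds shown here alone, is whether configuration at this carbon counts to the same extent when the double-bonded ring carbon carries another group, such as an amine or a longer chain.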